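The source may report more compounds than this note shows. Statements on the series, on what has been measured and on what is new or still open speak of the compounds shown alone.

Compound 2 `O=C(Nc1cccc2cnccc12)NC1CCc2cc(F)ccc2C1Cc1ccoc1` is the starting point for the next change. In an assay on HEK293 cells for displacement of a labelled ligand from transient receptor potential cation channel subfamily V member 1 (Homo sapiens) (a higher number here means a weaker inhibitor, a lower number a stronger inhibitor), compound 2 gives 16 nM. Compound 1 `O=C(Nc1cccc2cnccc12)NC1CCc2cc(F)ccc2C1Cc1ccccc1` carries phenyl where compound 2 carries furan-3-yl. In this assay compound 1 gives 4 nM. Compound 3 `COc1ccc2c(c1)CCC(NC(=O)Nc1cccc3cnccc13)C2Cc1cccnc1` differs from compound 2 in several places. In this assay compound 3 gives 1540 nM. Compound 2 therefore stands second highest of the three numbers, nearer to compound 1 than to compound 3. Within the data shown here, the one measured step at the position in question is a 4.0-fold higher number from compound 1 to compound 2 (0.60 log units; beyond the scatter).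

Compound 4 `O=C(Nc1cccc2cnccc12)NC1CCc2cc(F)ccc2C1CC1CC1` has not yet been measured in this assay. It differs from compound 2 as follows: cyclopropyl in place of furan-3-yl on a saturated chain carbon bound to a saturated ring carbon. Among the measured compounds shown here, the only measured step that bears on this change is a 4.0-fold higher number from compound 1 to compound 2 (0.60 log units; beyond the scatter), a modest one, so a step of comparable size is expected here, most likely towards a higher number, though the direction is not settled by the data. Compound 4 is expected to give 30 nM in this assay, with a range of 8 nM to 120 nM. This estimate corresponds to an expected 1.9-fold higher number from compound 2 to compound 4 (0.27 log units; within the scatter).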

Compound 4, inhibition constant: 0.8 nM
Estimate against measurement, compound 4: 38-fold (1.57 log units) above; measured number below the stated range.
By their numbers in this assay, from the lowest: compound 4; then compound 1; then compound 2; then compound 3.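

In this assay, an aromatic ring is not required on the saturated chain carbon bound to a saturated ring carbon: cyclopropyl gives a 20-fold lower number from compound 2 to compound 4 (1.30 log units; beyond the scatter) and a 5.0-fold lower number from compound 1 to compound 4 (0.70 log units; beyond the scatter). Among the three groups compared at this position, the only non-aromatic one therefore gives the lowest number, and the earlier phenyl and furan-3-yl pair did not reveal this. The replacement of furan-3-yl is the larger of the two new steps, while the step from phenyl is still beyond the scatter.

As far as these compounds go, it remains open whether the trend extends to cyclobutyl, to an open chain such as isopropyl, or to an amine such as piperidin-4-yl at this position. No measurement shown here explains the change in the number.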